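Working notes on the spiro series: benzyl to ethyl

The source may report more compounds than this note shows. Statements on the series, on what has been measured and on what is new or still open speak of the compounds shown alone.

Compound 1 `CN1C(=O)C2(C(C#N)=C(N)Oc3cc4oc(-c5ccccc5)cc(=O)c4c(O)c32)c2ccccc21` opens the set. In a functional assay on K562 cells (Homo sapiens) for antiproliferative activity, read by MTT assay, with a stated time of 48 h (on this read-out lower numbers stand for stronger inhibition and higher numbers for weaker inhibition), compound 1 gives only the limit > 50000 nM. Compound 2 `Cc1cccc2c1N(Cc1ccccc1)C(=O)C21C(C#N)=C(N)Oc2cc3oc(-c4ccccc4)cc(=O)c3c(O)c21` is the reference here. In this assay compound 2 likewise gives only the limit > 50000 nM. Compound 3 `N#CC1=C(N)Oc2cc3oc(-c4ccccc4)cc(=O)c3c(O)c2C12C(=O)N(Cc1ccccc1)c1c(Cl)cccc12` gives 47800 nM in this assay, and the step of an at least 1.0-fold lower number from compound 2 to compound 3 (0.01 log units; that floor lies within the scatter) lies within the scatter. Two of the three values sit at the ceiling (the limit of > 50000 nM in this assay, at which 2 of the 3 values shown sit). Compound 4 `CCN1C(=O)C2(C(C#N)=C(N)Oc3cc4oc(-c5ccccc5)cc(=O)c4c(O)c32)c2cccc(C)c21` differs from compound 2 by methyl in place of phenyl on a saturated chain carbon bound to an amide-type nitrogen in a ring. Within the data shown here, no measured step touches this position, so nothing points to a move beyond the scatter in this assay. Compound 4 is therefore expected near the ceiling, at about 50000 nM with a range from 20000 nM to 200000 nM. The estimated step is a number no higher from compound 2 to compound 4 (the limit leaves the size open), most likely reported again only as a limit.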

Compound 4, half-maximal inhibitory concentration: > 50000 nM
Compound 4 gave a limit, no number; the forecaster's own chance of this, stated with the estimate: 70%; the middle value lies on the limit itself.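

Compound 2 and compound 4 both give only limits, so no step between them can be read in this assay: the limit of > 50000 nM in this assay, at which 3 of the 4 values shown sit.

The compounds shown leave open what size of change, if any, benzyl to ethyl brings in this assay.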